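The source may report more compounds than this note shows. Statements on the series, on what has been measured and on what is new or still open speak of the compounds shown alone.

The measured compounds:

Compound 1, `CS(=O)(=O)Oc1ccc(-c2cncn2C2CCN(C(=O)c3ccc(Cl)c(C(F)(F)F)c3)CC2)cc1`: 1570 nM
Compound 2, `N#Cc1cccc(S(=O)(=O)Oc2ccc(-c3cncn3C3CCN(C(=O)c4ccc(Cl)c(C(F)(F)F)c4)CC3)cc2)c1`: 73 nM
Compound 3, `O=C(c1ccc(Cl)c(C(F)(F)F)c1)N1CCC(n2cncc2-c2ccc(OS(=O)(=O)c3cccc4cnccc34)cc2)CC1`: 45 nM

All three were tested in an assay on HEK293 cells for antagonist activity at P2X purinoceptor 7 (Homo sapiens), read by fluorescence, with a stated time of 2 h; on this read-out lower numbers stand for stronger inhibition and higher numbers for weaker inhibition. Compound 3 gives the lowest of the three numbers, at 45 nM, yet its gap to compound 2, a 1.6-fold lower number from compound 2 to compound 3 (0.21 log units; within the scatter), is within the scatter, so the two cannot be told apart. The large steps both start from compound 1: a 22-fold lower number from compound 1 to compound 2 (1.33 log units; beyond the scatter) and a 35-fold lower number from compound 1 to compound 3 (1.54 log units; beyond the scatter). Each of these changes only the group on the sulfonyl sulfur.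

Compound 4, `O=C(c1ccc([N+](=O)[O-])cc1)N1CCC(n2cncc2-c2ccc(OS(=O)(=O)c3cccc4cnccc34)cc2)CC1`, is not yet measured. It differs from compound 3 at another place: 4-nitrophenyl in place of 4-chloro-3-(trifluoromethyl)phenyl on a carbonyl carbon. Among the measured compounds shown here, no measured step touches this carbonyl-side group; every change seen so far sits on the sulfonyl sulfur, so the three measured steps give no direct guide to the size or direction of this one. The shared core and the isoquinolin-5-yl sulfonate are kept from compound 3, which is the only anchor available. Given that the group on the carbonyl carbon was held constant in every measured compound, compound 4 is estimated at 300 nM in this assay, with a range from 60 nM to 1500 nM, which means an expected step of a 6.7-fold higher number from compound 3 to compound 4 (0.82 log units; beyond the scatter).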

Compound 4, half-maximal inhibitory concentration: 1.49 nM
Compound 4: the middle estimate sits 200-fold (2.30 log units) above what was measured; measured number outside the range, below it.
By their numbers in this assay, from the lowest: compound 4; then compounds 3 and 2 (each within the scatter of the next); then compound 1.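

In this assay, the group on the carbonyl carbon proves to be a second strong lever: 4-nitrophenyl in place of 4-chloro-3-(trifluoromethyl)phenyl gives a 30-fold lower number from compound 3 to compound 4 (1.48 log units; beyond the scatter), a large step away from the sulfonyl sulfur, where changes such as a 35-fold lower number from compound 1 to compound 3 (1.54 log units; beyond the scatter) had been the only ones seen. The swap removes the chlorine and the trifluoromethyl group together and brings in the nitro group, taking the count from 11 heavy atoms to 9 and from 0 hydrogen-bond acceptors to 2, so several features change in this single step and the large drop in the number cannot be assigned to any one of them. No measurement on hand explains why this swap has such a large effect.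

Going by these compounds, it remains open whether the nitro group itself matters or whether losing the chlorine and trifluoromethyl group is enough, a question that a plain phenyl, a 4-aminophenyl or a 4-cyanophenyl on the carbonyl carbon could help to settle. It is also open whether 4-nitrophenyl gives a similar step alongside the 3-cyanophenyl on the sulfonyl sulfur, since the compounds shown pair it only with isoquinolin-5-yl.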